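The compounds below may be only part of what the source reports. "The series", "measured", "known", "first", "only" and "open" are said of these compounds alone.

Two compounds have so far been measured in a functional assay on HCT-116 cells (Homo sapiens) for inhibition, read by CCK-8 assay, with a stated time of 48 h; a lower number here means a stronger inhibitor, a higher number a weaker inhibitor:

compound 1 `COc1ccc(CN(C(=O)CSC(=S)N2CCOCC2)c2cc(OC)c(OC)c(OC)c2)cc1` gives 4130 nM
compound 2 `COc1cc(N(Cc2ccc(Br)cc2)C(=O)CSC(=S)N2CCN(C(=O)OC(C)(C)C)CC2)cc(OC)c1OC` gives 11400 nM

Compound 2 holds the higher of the two numbers in this assay; compound 1 sits at a lower value, and the gap between the two lies beyond the usual scatter of such measurements, so compound 2 is the weaker inhibitor of the pair as the data stand.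

The next compound, compound 3 `COc1ccc(CN(C(=O)CSC(=S)N2CCN(C(=O)OC(C)(C)C)CC2)c2cc(OC)c(OC)c(OC)c2)cc1O`, keeps the core of compound 2 and changes one group: 3-hydroxy-4-methoxyphenyl in place of 4-bromophenyl on a saturated chain carbon bound to an amide-type nitrogen. For the measured compounds named here, no directly comparable pair of measured compounds shows what this change does, so any expectation rests on the two values above alone. Going by the values given here, compound 3 carries a substituted benzyl group that resembles the one in compound 1 more than the one in compound 2, and the only firm anchor is that compound 2 stands at 11400 nM in this assay.

The step from compound 2 to compound 3 is expected to lower the number by a modest amount, a 1.6-fold lower number from compound 2 to compound 3 (0.21 log units; within the scatter), at most just beyond the scatter. Compound 3 is therefore estimated at 7000 nM, within a range of 2500 nM to 20000 nM.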

Compound 3, half-maximal inhibitory concentration: 128 nM
Compound 3: the middle estimate sits 55-fold (1.74 log units) above what was measured, outside the stated range (below it).
By their numbers in this assay, from the lowest: compound 3; then compound 1; then compound 2.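

In this assay, the group on a saturated chain carbon bound to an amide-type nitrogen proves to be a place where a single exchange has a large effect: 3-hydroxy-4-methoxyphenyl in place of 4-bromophenyl gives an 89-fold lower number from compound 2 to compound 3 (1.95 log units; beyond the scatter) with the rest of the structure unchanged. For the compounds shown here, compound 1 and compound 2 differ in more than one place, so they could not show what this position does alone, and this is the first step that isolates it. Nothing measured here accounts for the size of the step, which therefore remains an observation without an explanation.

The exchange removes the bromine and brings in a hydroxy and a methoxy group in one step, so the compounds shown do not separate what each of these contributes, and 3-hydroxyphenyl or 4-methoxyphenyl alone at this place would be needed to tell them apart. On these data alone, it also remains open whether an amine in place of the hydroxy group would keep the low number, and whether the same exchange would have a similar effect on the core of compound 1.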